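Aryl variation on a glucagon receptor antagonist series

The source may hold more compounds than are shown below. What is called first, only, known or untested is meant among the compounds shown, and "the series" means these compounds.

Compounds measured so far:
compound 1, `CCCC(Oc1cnn(-c2ccc(C(F)(F)F)cn2)c1)c1ccc(C(=O)NCCC(=O)O)cc1`: 16400 nM
compound 2, `CCCC(Oc1cnn(-c2cccc(C)c2)c1)c1ccc(C(=O)NCCC(=O)O)cc1`: > 20900 nM
compound 3, `CCCC(Oc1cnn(-c2cccc(CC)c2)c1)c1ccc(C(=O)NCCC(=O)O)cc1`: 4530 nM

The three measured compounds share one core and differ only in the aromatic group on the ring nitrogen. In a functional assay on cells for antagonist activity at Glucagon receptor (Homo sapiens), read by cAMP accumulation (a higher number here means a weaker inhibitor, a lower number a stronger inhibitor), compound 3 gives 4530 nM, the lowest of the two numbers, the nearest being compound 1 at 16400 nM. For compound 2 the value of > 20900 nM is a limit of this assay, not a number (the limit of > 20900 nM in this assay, at which 1 of the 3 values shown sits). The step of a 3.6-fold lower number from compound 1 to compound 3 (0.56 log units; beyond the scatter) and the step of an at least 4.6-fold lower number from compound 2 to compound 3 (0.66 log units; beyond the scatter) both point the same way: the 3-ethylphenyl group gives the strongest inhibition of the three.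

Compound 4, `CCCC(Oc1cnn(-c2ccc(Cl)cc2)c1)c1ccc(C(=O)NCCC(=O)O)cc1`, has not yet been measured. The change is 4-chlorophenyl in place of 3-ethylphenyl on an aromatic nitrogen. Within the data shown here, no measured step covers this change directly; the nearest are the two steps into compound 3, both beyond the scatter, which show that replacing 3-ethylphenyl weakened inhibition. A chlorine in place of an ethyl, and at another place on the ring, is therefore expected to raise the number in this assay, by a step estimated at a 3.3-fold higher number from compound 3 to compound 4 (0.52 log units; beyond the scatter). Compound 4 is estimated at 15000 nM, within a range from 5000 nM to 30000 nM, with a real chance that only a limit is reported.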

Compound 4, antagonist equilibrium constant: > 7520 nM
Compound 4: only a limit was reported; the forecaster's own chance of this, stated with the estimate: 40%; the middle value does not contradict the limit.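

Compound 4 is the only one of the four with a chlorine on its aromatic group, and its reading is a limit: the limit of > 7520 nM in this assay, at which 1 of the 4 values shown sits.

In this assay, the change from 3-ethylphenyl to 4-chlorophenyl gives an at least 1.6-fold higher number from compound 3 to compound 4 (0.22 log units; that floor lies within the scatter), so this reading does not establish that 4-chlorophenyl is a weaker choice at this position than 3-ethylphenyl, and the true size of the step could be small or large. The steps linking compound 4 with compound 1 and compound 2 cannot be read, which leaves compound 4 unplaced relative to both.

Compound 4 differs from compound 3 in both the group and its place on the ring, so the compounds shown cannot separate the effect of the chlorine from that of its place, and a 3-chlorophenyl group would be the direct test of that. As far as these compounds go, whether a longer chain, as in a 3-propylphenyl group, would lower the number further than the 3-ethylphenyl group of compound 3 also remains open.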